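The source may report more compounds than this note shows. Statements on the series, on what has been measured and on what is new or still open speak of the compounds shown alone.

Three compounds have been measured in an assay on CHO-K1 cells for displacement of a labelled ligand from melanin-concentrating hormone receptor 1 (Homo sapiens), read by scintillation proximity assay, with a stated time of 2 h; a higher number here means a weaker inhibitor, a lower number a stronger inhibitor:

Compound 1, `Cc1ccc(/C=C/C(=O)Nc2ccc3nc(N4CCC(O)(C5CC5)CC4)nc(C)c3c2)cc1`, gives 344 nM.
Compound 2, `Cc1nc(N2CCC(N3C(=O)CCC3=O)CC2)nc2ccc(NC(=O)/C=C/c3ccc(OC(F)(F)F)cc3)cc12`, gives 94 nM.
Compound 3, `COCCC1(O)CCN(c2nc(C)c3cc(NC(=O)/C=C/c4ccc(Cl)cc4)ccc3n2)CC1`, gives 245 nM.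

All three share one core, a fused ring system carrying a methyl group, a six-membered saturated nitrogen ring on one side and an unsaturated amide on the other; they differ in what the saturated ring bears and in the substituent on the far aromatic ring. Among the three numbers, compound 2 stands lowest, which in this assay means it is the strongest inhibitor of the set. Its gap to compound 3 is beyond the usual scatter of repeated measurements, and its gap to compound 1 is wider still.

Compound 4, `Cc1nc(N2CCC(N3CCOC3=O)CC2)nc2ccc(NC(=O)/C=C/c3ccc(OC(F)(F)F)cc3)cc12`, has not yet been measured. It keeps everything in compound 2 except one ring: 2-oxo-1,3-oxazolidin-3-yl in place of 2,5-dioxopyrrolidin-1-yl on a saturated ring carbon. Going by the values given here, no measured pair shows the effect of this particular exchange, so the direction of the step is uncertain. Because compound 2 gives 94 nM and the exchanged ring is close in size and in counted acceptors to the one it replaces, the step is expected to be small, roughly within the scatter, with a slight lean toward a weaker inhibitor; the estimate for the step is a 1.3-fold higher number from compound 2 to compound 4 (0.11 log units; within the scatter). Compound 4 is therefore expected to give about 120 nM in this assay, with a range from 50 nM to 300 nM.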

Compound 4, half-maximal inhibitory concentration: 41 nM
The estimate for compound 4 lay 2.9-fold (0.47 log units) above the measured number; measured number outside the range, below it.
By their numbers in this assay, from the lowest: compound 4; then compound 2; then compounds 3 and 1 (each within the scatter of the next).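

The exchange gives a 2.3-fold lower number from compound 2 to compound 4 (0.36 log units; beyond the scatter) in this assay and so shows that the number responds to a change between two five-membered non-aromatic rings on this saturated ring carbon, three ring bonds from the ring nitrogen. On paper the change is slight: 2-oxo-1,3-oxazolidin-3-yl has 6 heavy atoms in place of 7, 1 double bond outside aromatic rings in place of 2 and 2 ring hetero atoms in place of 1, while 2,5-dioxopyrrolidin-1-yl has the same counts of hydrogen-bond donors and acceptors, so matching counts did not give matching numbers in this pair. Nothing available here explains the direction of the step, and this single pair cannot show which of these differences carries it.

A 2-oxopyrrolidin-1-yl ring or an open-chain acetamido group on the same carbon would help separate those differences, but neither is among the compounds shown. Also open, from the compounds shown here alone, is whether the step holds when the far aromatic ring carries a chlorine or a methyl group instead of trifluoromethoxy.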